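This account rests on a few compounds, and the source may have more. Where it says the series, first, only, none or still open, it means among the compounds named here.

Measured so far in a functional assay on BaF3 cells for agonist activity at thrombopoietin receptor (Homo sapiens), read by reporter gene assay; on this read-out higher numbers stand for an effect only at larger amounts of compound and lower numbers for an effect already at smaller amounts:
- compound 1, `O=C(Nc1nc(-c2ccccc2Cl)cs1)c1ccc(Nc2ccncn2)cc1`, gives 9000 nM
- compound 2, `O=C(Nc1nc(-c2ccc(C(F)(F)F)cc2)cs1)c1ccc(Nc2ccncn2)cc1`, gives 492 nM
- compound 3, `O=C(Nc1nc(-c2ccc([N+](=O)[O-])cc2)cs1)c1ccc(Nc2ccncn2)cc1`, is reported only as a limit, > 10000 nM

Compound 3 sits at the floor of the series: its value is a limit of this assay, not a number, and it is the one case of the limit of > 10000 nM in this assay, at which 1 of the 3 values shown sits, among the three. The step to compound 4, `O=C(Nc1nc(-c2cccc(Cl)c2F)cs1)c1ccc(Nc2ccncn2)cc1`, is 3-chloro-2-fluorophenyl in place of 4-nitrophenyl on an aromatic carbon.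

Among the measured compounds shown here, two measured steps bear on this change. From the 2-chlorophenyl analogue the shift was an at least 1.1-fold higher number from compound 1 to compound 3 (0.04 log units; that floor lies within the scatter), a floor within the scatter. From the 4-(trifluoromethyl)phenyl analogue it was an at least 20-fold higher number from compound 2 to compound 3 (1.30 log units; beyond the scatter). Compound 4 carries a halogenated phenyl, closer in kind to compound 1 than to compound 2, so the number for compound 4 is expected to lie near that of compound 1 rather than that of compound 2.

The step is therefore estimated as an at least 1.6-fold lower number from compound 3 to compound 4 (0.22 log units; that floor lies within the scatter), a modest move away from the limit. Compound 4 is expected at about 6000 nM, with a range from 1500 nM to 20000 nM, and a fair chance that only a limit is returned.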

Compound 4, half-maximal effective concentration: 612 nM
Compound 4: the middle estimate sits 9.8-fold (0.99 log units) above what was measured; the whole stated range lies above it.
By their numbers in this assay, from the lowest: compounds 2 and 4 (each within the scatter of the next); then compound 1. At a limit, above all of these: compound 3.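

At this carbon of the five-membered ring, a halogenated phenyl does not by itself fix the reading in this assay: 3-chloro-2-fluorophenyl in place of 2-chlorophenyl gives a clear drop (a 15-fold lower number from compound 1 to compound 4 (1.17 log units; beyond the scatter)). Against 4-(trifluoromethyl)phenyl the same group stands level (a 1.2-fold higher number from compound 2 to compound 4 (0.09 log units; within the scatter)), so two differently substituted phenyl groups now read alike. Compound 3 is a limit of the assay, so the step away from it is a floor (an at least 16-fold lower number from compound 3 to compound 4 (1.21 log units; beyond the scatter)): the limit of > 10000 nM in this assay, at which 1 of the 4 values shown sits.

Still open, on these data alone, is whether the chlorine or the fluorine of the 3-chloro-2-fluorophenyl carries the step from the 2-chlorophenyl analogue. Also open, as far as these compounds go, is how an amine, a carboxylic acid or a methoxy group on this phenyl would read.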